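Swapping the hydrazone aryl group in a weak HCT-116 series

A few compounds are considered here, and "the series" means these few. Any claim that something is new, unique, unknown or untested is made for them only; others in the source may bear on it.

Compound 3 `COc1ccc(/C=N/NC(=O)CSc2nnc(-c3ccncc3)n2-c2ccccc2)cc1` is one of three close relatives tested in a functional assay on HCT-116 cells (Homo sapiens) for inhibition, read by MTT assay, with a stated time of 48 h; a lower number here means a stronger inhibitor, a higher number a weaker inhibitor. Compound 1 `Brc1cccc(CSc2nnc(-c3ccncc3)n2-c2ccccc2)c1` gives 8170 nM in this assay. Compound 2 `O=[N+]([O-])c1ccccc1CSc1nnc(-c2ccncc2)n1-c1ccccc1` reaches only the limit of the assay, > 50000 nM, so no number is known for it. Compound 3 gives 19200 nM in this assay, the higher of the two numbers available, and its nearest neighbour is compound 1 with a value lower by a margin beyond the scatter.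

Compound 4 `O=C(CSc1nnc(-c2ccncc2)n1-c1ccccc1)N/N=C/C=C/c1ccccc1` has not yet been measured. It differs from compound 3 in one place: 2-phenylethenyl in place of 4-methoxyphenyl on a carbon with a double bond to nitrogen. Among the measured compounds shown here, the only measured step in this set is an at least 6.1-fold higher number from compound 1 to compound 2 (0.78 log units; beyond the scatter); it concerns a different part of the molecule and a different pair of groups, so it does not speak to this change. With nothing that bears directly, the change is expected to give at most a small step, a 1.1-fold higher number from compound 3 to compound 4 (0.06 log units; within the scatter), in either direction. Compound 4 is therefore expected to give about 22000 nM in this assay, within roughly 8000 nM to 50000 nM.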

Compound 4, half-maximal inhibitory concentration: 6150 nM
The estimate for compound 4 lay 3.6-fold (0.55 log units) above the measured number; the measured number lies below the stated range.
By their numbers in this assay, from the lowest: compounds 4 and 1 (each within the scatter of the next); then compound 3. At a limit, above all of these: compound 2.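

In this assay the swap of 4-methoxyphenyl for 2-phenylethenyl gives a 3.1-fold lower number from compound 3 to compound 4 (0.49 log units; beyond the scatter) and so shows that the group on a carbon with a double bond to nitrogen can change the result by more than the usual scatter. The two groups hold the same number of heavy atoms and each carries one six-membered aromatic ring of carbon only, so the step comes with a swap that leaves both of those counts as they were. What differs is the oxygen of 4-methoxyphenyl and the double bond outside aromatic rings in 2-phenylethenyl, and nothing shown here tells which of these accounts for the step.

A single pair cannot show whether the double bond or the loss of the methoxy oxygen matters more, and a plain phenyl group at this place would help to separate the two. On these data alone, how an amine or a carboxylic acid on the aromatic ring of 2-phenylethenyl, or a longer chain of double bonds, would behave here also remains open.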